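A few compounds are considered here, and "the series" means these few. Any claim that something is new, unique, unknown or untested is made for them only; others in the source may bear on it.

Values from an assay on 1321N1 cells for antagonist activity at P2Y purinoceptor 6 (Mus musculus), read by FLIPR and calcium flux; a higher number here means a weaker inhibitor, a lower number a stronger inhibitor:

- compound 1, `O=[N+]([O-])C1=Cc2cccc(I)c2OC1C(F)(F)F`: 17600 nM
- compound 2, `O=[N+]([O-])C1=Cc2cccc(Cl)c2OC1C(F)(F)F`: 15200 nM
- compound 3, `O=[N+]([O-])C1=Cc2ccccc2OC1C(F)(F)F`: 185000 nM

Compound 3 shows the highest number of the three in this assay, and the gaps to both halogen-bearing compounds are large: an 11-fold higher number from compound 1 to compound 3 (1.02 log units; beyond the scatter) and a 12-fold higher number from compound 2 to compound 3 (1.09 log units; beyond the scatter). Between the two halogens themselves the numbers hardly differ, a 1.2-fold lower number from compound 1 to compound 2 (0.06 log units; within the scatter).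

Compound 4, `O=[N+]([O-])C1=Cc2cc(Br)ccc2OC1C(F)(F)F`, differs from compound 3 by bromo in place of hydrogen on an aromatic carbon. The two measured steps bear on this only in part: they show that removing a halogen from an aromatic carbon of the shared core raises the number sharply, but they concern iodo and chloro, and the place of the bromo in compound 4 is given as meta to a fused ring and para to a fused ring, which cannot be matched to those steps from the numbers shown. Adding a halogen is therefore expected to lower the number, but with less confidence in the size. For compound 4 the estimated step is a 3.7-fold lower number from compound 3 to compound 4 (0.57 log units; beyond the scatter), and the expected value in this assay is 50000 nM, within a range of 12000 nM to 190000 nM.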

Compound 4, half-maximal inhibitory concentration: 20200 nM
Estimate against measurement, compound 4: 2.5-fold (0.39 log units) above; low and high end bracket the measured number.
By their numbers in this assay, from the lowest: compounds 2, 1 and 4 (each within the scatter of the next); then compound 3.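

In this assay, putting bromo in place of hydrogen on this aromatic carbon, meta to a fused ring and para to a fused ring, gives a 9.2-fold lower number from compound 3 to compound 4 (0.96 log units; beyond the scatter). The lower number on adding a halogen to the shared core is therefore not confined to the aromatic carbon that carries iodo in compound 1 and chloro in compound 2, and it extends to a third halogen. Nothing available explains why this change has this effect.

The compounds shown leave open whether chloro or iodo on this carbon would give a number like that of compound 4, and how bromo would behave on the carbon used in compound 1 and compound 2. They also leave open whether a non-halogen group here, such as a methyl, a methoxy or an amine, would lower the number as well.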